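A Methoxy Group Takes the Place of Chlorine

This account rests on a few compounds, and the source may have more. Where it says the series, first, only, none or still open, it means among the compounds named here.

Three compounds share one core and differ only in the group on one outer six-membered ring of carbon only. Compound 1 `O=C(/C=C\Nc1ccc(Cl)cc1)c1cn(-c2ccccc2)nc1-c1ccccc1` carries hydrogen there; in an ADME assay on HaCaT cells (Homo sapiens) for antiproliferative activity, read by MTT assay, with a stated time of 48 h (a lower number here means a stronger inhibitor, a higher number a weaker inhibitor), compound 1 gives 28400 nM. Compound 2 `O=C(/C=C\Nc1ccc(Cl)cc1)c1cn(-c2ccccc2)nc1-c1ccc(F)cc1` carries fluoro there, and in this assay compound 2 gives 21300 nM. Compound 3 `O=C(/C=C\Nc1ccc(Cl)cc1)c1cn(-c2ccccc2)nc1-c1ccc(Cl)cc1` carries chloro there, and in this assay compound 3 gives 23400 nM. The three numbers sit close together: a 1.3-fold lower number from compound 1 to compound 2 (0.12 log units; within the scatter), a 1.2-fold lower number from compound 1 to compound 3 (0.08 log units; within the scatter), and a 1.1-fold higher number from compound 2 to compound 3 (0.04 log units; within the scatter). Compound 3 thus lies among three numbers that this assay cannot tell apart.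

Compound 4 `COc1ccc(-c2nn(-c3ccccc3)cc2C(=O)/C=C\Nc2ccc(Cl)cc2)cc1` differs from compound 3 in one place: methoxy in place of chloro on an aromatic carbon. Within the data shown here, no measured step puts methoxy on this ring, so the expectation rests on the three steps above, all of which stayed within the scatter whether hydrogen, fluoro or chloro sat on this aromatic carbon. The step from compound 3 to compound 4 is therefore expected to be small, a 1.0-fold lower number from compound 3 to compound 4 (0.01 log units; within the scatter). Compound 4 is estimated at 23000 nM in this assay, with a range from 11000 nM to 48000 nM.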

Compound 4, half-maximal inhibitory concentration: 20900 nM
The estimate for compound 4 lay 1.1-fold (0.04 log units) above the measured number; the measured number falls inside the stated range.
By their numbers in this assay, from the lowest: compounds 4, 2, 3 and 1 (each within the scatter of the next).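

In this assay, methoxy, with two heavy atoms where chloro has one and with a hydrogen-bond acceptor where chloro has none, still stays within the scatter of all three earlier compounds: a 1.1-fold lower number from compound 3 to compound 4 (0.05 log units; within the scatter), a 1.0-fold lower number from compound 2 to compound 4 (0.01 log units; within the scatter) and a 1.4-fold lower number from compound 1 to compound 4 (0.13 log units; within the scatter). The earlier compounds shown here showed this only for hydrogen, fluoro and chloro; the position now holds four different groups, including one that brings in oxygen, and this assay cannot tell any of the four compounds apart. No evidence is available on why the number stays so flat across these changes.

As far as these compounds go, whether an amine, a carboxylic acid or a longer chain such as butoxy on this aromatic carbon would move the number beyond the scatter remains open. From the compounds shown here alone, all four compounds also share the 4-chlorophenyl group on the nitrogen end of the core and are compared in one assay only, so it is equally open whether the same flat picture would hold with a different group there or in other cells.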